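Dropping one hydroxy from 3,4-dihydroxyphenyl

The source may hold more compounds than are shown below. What is called first, only, known or untested is meant among the compounds shown, and "the series" means these compounds.

In a functional assay on A2780 cells (Homo sapiens) for inhibition, read by trypan blue exclusion, with a stated time of 72 h (a higher number here means a weaker inhibitor of growth, a lower number a stronger inhibitor of growth), compound 1 `CCCn1c(-c2ccc(O)c(O)c2)c(C)c2cc(O)ccc21` gives 8400 nM and compound 2 `Cc1c(-c2ccc(O)c(O)c2)n(CCCCOc2ccccc2)c2ccc(O)cc12` gives 4300 nM as its reading. Within the data shown here, these two stand level, with a 2.0-fold lower number from compound 1 to compound 2 (0.29 log units; within the scatter) as the only measured step. Compound 3 `Cc1c(-c2ccc(O)cc2)n(CCCCOc2ccccc2)c2ccc(O)cc12` differs from compound 2 by hydrogen in place of hydroxy on an aromatic carbon in one place: hydrogen in place of hydroxy on an aromatic carbon, turning 3,4-dihydroxyphenyl into 4-hydroxyphenyl. Among the measured compounds shown here, the measured step altered the chain instead, so no measured step bears on this change and the data set no direction. The expected step is a 1.2-fold higher number from compound 2 to compound 3 (0.07 log units; within the scatter) and none beyond the scatter, though with wide uncertainty. Compound 3 is estimated at 5000 nM (range 1700 nM to 15000 nM).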

Compound 3, concentration for 50% growth inhibition: 2000 nM
For compound 3 the middle estimate is 2.5-fold (0.40 log units) above the measured one; the measured number falls inside the stated range.
By their numbers in this assay, from the lowest: compound 3; then compounds 2 and 1 (each within the scatter of the next).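

Replacing this hydroxy with hydrogen does not weaken growth inhibition: in this assay there is a 2.2-fold lower number from compound 2 to compound 3 (0.33 log units; beyond the scatter). Among these compounds, this modest gain is the first step here beyond the scatter, and it shows that 3,4-dihydroxyphenyl is not required at this position, since 4-hydroxyphenyl serves at least as well. Nothing available explains why the number falls. Still open, on these data alone, is whether the remaining hydroxy matters, and how a methoxy group or an amine on the vacated aromatic carbon would compare with hydrogen.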